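Swapping a Thiophene for a Benzyl Group on the Shared Core

A few compounds are considered here, and "the series" means these few. Any claim that something is new, unique, unknown or untested is made for them only; others in the source may bear on it.

Three compounds that share one core and differ only in the group attached to an aromatic carbon of the fused two-ring system have been measured in a functional assay on L1210 cells (Mus musculus) for inhibition, read by cell counting, with a stated time of 2 days; on this read-out higher numbers stand for weaker inhibition and lower numbers for stronger inhibition. Compound 1 `C=C(Br)C(=O)Nc1cccc(-c2cn3nc(-c4ccc(OC)c(OC)c4)sc3n2)c1` gives 42 nM. Compound 2 `C=C(Br)C(=O)Nc1cccc(-c2cn3nc(CCc4ccccc4)sc3n2)c1` gives 2200 nM. Compound 3 `C=C(Br)C(=O)Nc1cccc(-c2cn3nc(-c4cccs4)sc3n2)c1` gives 170 nM, which places it second highest of the three numbers, with a 4.0-fold higher number from compound 1 to compound 3 (0.61 log units; beyond the scatter) and a 13-fold lower number from compound 2 to compound 3 (1.11 log units; beyond the scatter).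

Compound 4 `C=C(Br)C(=O)Nc1cccc(-c2cn3nc(Cc4ccccc4)sc3n2)c1` has not yet been measured. It differs from compound 3 as follows: benzyl in place of thiophen-2-yl on an aromatic carbon.

Going by the values given here, two measured steps bear on this change. The step from the phenethyl compound to the thiophen-2-yl compound was large, a 13-fold lower number from compound 2 to compound 3 (1.11 log units; beyond the scatter), and the related step of a 52-fold higher number from compound 1 to compound 2 (1.72 log units; beyond the scatter) was large as well. In both, replacing a ring attached directly to the core with a chain carrying a phenyl ring gave a much higher number. Benzyl is such a chain, one carbon shorter than phenethyl, so a rise in the number is expected in this assay, though perhaps not as far as compound 2 reached. Compound 4 is therefore expected to show a 4.7-fold higher number from compound 3 to compound 4 (0.67 log units; beyond the scatter). The estimate for compound 4 is 800 nM, with a range from 250 nM to 2500 nM.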

Compound 4, half-maximal inhibitory concentration: 3000 nM
Beside the measured number, compound 4's estimate is 3.8-fold (0.57 log units) below it; measured number above the stated range.
By their numbers in this assay, from the lowest: compound 1; then compound 3; then compounds 2 and 4 (each within the scatter of the next).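

Benzyl on this aromatic carbon does not land partway between phenethyl and the directly attached rings: in this assay, the two chain compounds cannot be told apart (a 1.4-fold higher number from compound 2 to compound 4 (0.13 log units; within the scatter)), so the difference between these two chains has no readable effect on the number. Replacing a directly attached ring with benzyl gives a large step whether that ring is thiophen-2-yl (an 18-fold higher number from compound 3 to compound 4 (1.25 log units; beyond the scatter)) or 3,4-dimethoxyphenyl (a 71-fold higher number from compound 1 to compound 4 (1.85 log units; beyond the scatter)), so compound 1 and compound 3, with a ring bound directly to the core, have lower numbers than compound 2 and compound 4, with a ring carried on a chain, and none of the four goes against this split. No measurement shown here explains this split.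

A plain phenyl ring or a pyridine ring attached directly would test whether the split holds for other directly bound rings, while a 3,4-dimethoxybenzyl group would show whether the methoxy groups can offset the effect of the chain. On these data alone, it also remains open whether a longer chain ending in phenyl or a chain ending in an amine would stay with compound 2 and compound 4.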